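Moving the Pyridine Nitrogen: Cytotoxicity Outlook

The compounds below may be only part of what the source reports. "The series", "measured", "known", "first", "only" and "open" are said of these compounds alone.

Compound 1, `Cc1ccc(CCOc2ccc(-c3c(C)nc(C)c([C@H](OC(C)(C)C)C(=O)O)c3N3CCC(C)(C)CC3)cc2)cc1`: in a toxicity assay on MT2 cells (Homo sapiens) for cytotoxicity, read by XTT assay, with a stated time of 4 days (on this read-out higher numbers stand for lower toxicity in this test and lower numbers for higher toxicity in this test), compound 1 gives >= 33500 nM, which is a limit of the assay rather than a number.
Compound 2, `Cc1nc(C)c([C@H](OC(C)(C)C)C(=O)O)c(N2CCC(C)(C)CC2)c1-c1ccc(OCCc2cccnc2)cc1`: in this assay compound 2 gives >= 25000 nM, again a limit of the assay.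

Compound 2 therefore stands at the edge of what this assay reports, with no toxicity resolved within the tested range. Compound 3, `Cc1nc(C)c([C@H](OC(C)(C)C)C(=O)O)c(N2CCC(C)(C)CC2)c1-c1ccc(OCCc2ccncc2)cc1`, differs from compound 2 by pyridin-4-yl in place of pyridin-3-yl on a saturated chain carbon, two bonds along the chain from an oxygen on an aromatic ring. Among the compounds with values here, the only measured step that touches this part of the molecule is a step that the two limits leave unreadable from compound 1 to compound 2, and it stays unreadable because the limit of >= 25000 nM in this assay, at which 1 of the 2 values shown sits, and the limit of >= 33500 nM in this assay, at which 1 of the 2 values shown sits, cap both ends of it. No measured evidence therefore points to any movement in this assay for the present change. Compound 3 is expected to show a step that the limit leaves unreadable from compound 2 to compound 3, that is, nothing beyond the usual scatter. Compound 3 is accordingly estimated at 30000 nM, within 15000 nM to 60000 nM, and most likely reported as a limit once more.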

Compound 3, half-maximal cytotoxic concentration: >= 25000 nM
Compound 3: no number, only a limit (the forecaster's own chance of this, stated with the estimate: 80%); the middle value is on the limit's open side.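

No step among compound 1, compound 2 and compound 3 can be read in this assay, since all three values are limits of the assay rather than numbers: the limit of >= 25000 nM in this assay, at which 2 of the 3 values shown sit.

The compounds shown leave open at what concentration any of them becomes toxic in this assay, and whether pyridin-3-yl, pyridin-4-yl and 4-methylphenyl differ there at all.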